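Replacing the 2-methylphenyl group of compound 2

The source may report more compounds than this note shows. Statements on the series, on what has been measured and on what is new or still open speak of the compounds shown alone.

Of the compounds shown here, two with a shared core have so far been measured in a functional assay on DU-145 cells (Homo sapiens) for inhibition, read by MTT assay, with a stated time of 72 h; on this read-out lower numbers stand for stronger inhibition and higher numbers for weaker inhibition. Compound 1 `O=C1C=C(N2CCN(c3ccc(Cl)cc3)CC2)C(=O)c2ccccc21` gives 29500 nM, and compound 2 `Cc1ccccc1N1CCN(C2=CC(=O)c3ccccc3C2=O)CC1` gives 5700 nM, the lower of the two numbers. For the measured compounds named here, the only measured step, a 5.2-fold lower number from compound 1 to compound 2 (0.71 log units; beyond the scatter), puts 2-methylphenyl in place of 4-chlorophenyl on an amine nitrogen in a ring.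

Compound 3 `O=C1C=C(N2CCN(c3ccc(F)c(Cl)c3)CC2)C(=O)c2ccccc21` has not yet been measured. It carries 3-chloro-4-fluorophenyl in place of 2-methylphenyl on an amine nitrogen in a ring. Going by the values given here, the entering group has a chloro substituent, as the 4-chlorophenyl group of compound 1 does, but no measured compound carries fluoro. Among the compounds with values here, the single step of a 5.2-fold lower number from compound 1 to compound 2 (0.71 log units; beyond the scatter) is therefore the only guide, and it is thin evidence. Leaving 2-methylphenyl is expected to give back part of that step, not all of it. In this assay the estimated step is a 2.1-fold higher number from compound 2 to compound 3 (0.32 log units; beyond the scatter). For compound 3 the estimated value is 12000 nM, with an expected range from 4000 nM to 35000 nM.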

Compound 3, half-maximal inhibitory concentration: 32200 nM
Beside the measured number, compound 3's estimate is 2.7-fold (0.43 log units) below it, and the stated range covers the measured number.
By their numbers in this assay, from the lowest: compound 2; then compounds 1 and 3 (each within the scatter of the next).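

In this assay, the second change of aryl group on this amine nitrogen gives a 5.6-fold higher number from compound 2 to compound 3 (0.75 log units; beyond the scatter), which leaves compound 2 as the strongest of the three, with steps beyond the scatter to both of the others, and so ties the lower number, among these compounds only, to 2-methylphenyl. The two groups that carry chloro cannot be told apart, for the exchange of 4-chlorophenyl for 3-chloro-4-fluorophenyl reads a 1.1-fold higher number from compound 1 to compound 3 (0.04 log units; within the scatter), so the first fluoro substituent in the series, together with the different chloro pattern, brings no difference that this read-out can separate. Nothing is available here that would explain why these groups give the numbers they do.

The compounds shown leave open whether the lower number of compound 2 belongs to its methyl group as such or merely to the absence of chloro and fluoro, a question that an unsubstituted phenyl group on the same nitrogen could help to settle. They also leave open how a methoxy-bearing phenyl group or a pyridine ring would behave at this position, and whether any group here can go well beyond compound 2.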